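A few compounds are considered here, and "the series" means these few. Any claim that something is new, unique, unknown or untested is made for them only; others in the source may bear on it.

Compound 2 `O=C(Nc1nn[nH]n1)c1cc(Cl)ccn1` is the carboxamide that, in a functional assay on the whole organism for inhibition, with Rattus norvegicus as the target, at a dose of 1 mg/kg by the oral route (on this read-out lower numbers stand for a weaker effect and higher numbers for a stronger effect at the one dose given), gives 38%. For the measured compounds named here, its one neighbour among the measured compounds is compound 1 `CC(C)c1ccnc(C(=O)Nc2nn[nH]n2)c1`, which carries an isopropyl group where compound 2 carries chloro; in this assay compound 1 gives 36%. Going by the values given here, the sole measured step, a number 2 percentage points higher from compound 1 to compound 2 (within the scatter), shows that swapping these two groups on the aromatic carbon leaves the number where it was. Among the compounds with values here, compound 2 therefore stands at the top of only two numbers, and only within the scatter of compound 1.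

Compound 3 `O=C(Nc1nn[nH]n1)c1ccccn1` removes the substituent altogether: hydrogen in place of chloro on an aromatic carbon. Within the data shown here, no measured step covers the loss of a group at this carbon, so the step from compound 1 to compound 2 bears on it only in showing that two rather different groups there gave the same read-out. The step is expected to be small, a number 8 percentage points lower from compound 2 to compound 3 (within the scatter), and not clearly beyond the scatter. Compound 3 is estimated at 30% in this assay, within a range from 8% to 52%.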

Compound 3, a percentage reported as inhibition, in the whole organism at one dose (the size of the read-out at that dose, not a potency): 0%
Compound 3: middle estimate off by 30 percentage points, on the high side; the measured number lies below the stated range.
By their numbers in this assay, from the lowest: compound 3; then compounds 1 and 2 (each within the scatter of the next).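

In this assay hydrogen in place of chloro on this aromatic carbon, opposite the ring nitrogen, gives a number 38 percentage points lower from compound 2 to compound 3 (beyond the scatter) and hydrogen in place of isopropyl gives a number 36 percentage points lower from compound 1 to compound 3 (beyond the scatter) so both groups stand clearly apart from hydrogen. The earlier step had shown only that chloro and isopropyl could be exchanged without moving the number, whereas these steps show that, among these three compounds, having a group on this carbon at all separates a clear effect from the loss of it. Nothing measured here explains why hydrogen differs so sharply from both groups.

The compounds shown leave open whether other groups on this carbon, such as methoxy, an amine or a longer chain, would match chloro and isopropyl or go beyond them.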